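The source may hold more compounds than are shown below. What is called first, only, known or untested is meant among the compounds shown, and "the series" means these compounds.

Measured compounds in an assay on HEK293 cells for displacement of a labelled ligand from adenosine receptor A2b (Homo sapiens); a lower number here means a stronger inhibitor, a higher number a weaker inhibitor:

compound 1 `Cn1c(=O)c2[nH]c(-c3ccc(S(=O)(=O)N4CCN(Cc5ccc(Cl)s5)CC4)cc3)cc2n(C)c1=O`: 4 nM
compound 2 `Cn1c(=O)c2[nH]c(-c3ccc(S(=O)(=O)N4CCN(Cc5ccc(Br)cc5)CC4)cc3)cc2n(C)c1=O`: 1 nM
compound 3 `Cn1c(=O)c2[nH]c(-c3ccc(S(=O)(=O)N4CCN(Cc5ccc(F)cc5F)CC4)cc3)cc2n(C)c1=O`: 7 nM

Compound 3 stands at the highest of the three numbers. Its gap to compound 1, the step of a 1.8-fold higher number from compound 1 to compound 3 (0.24 log units; within the scatter), is within the scatter; its gap to compound 2, the step of a 7.0-fold higher number from compound 2 to compound 3 (0.85 log units; beyond the scatter), is beyond it. The remaining measured step, a 4.0-fold lower number from compound 1 to compound 2 (0.60 log units; beyond the scatter), is of a similar modest size.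

Compound 4 `Cn1c(=O)c2[nH]c(-c3ccc(S(=O)(=O)N4CCN(c5ccccc5)CC4)cc3)cc2n(C)c1=O` differs from compound 3 in one place: phenyl in place of 2,4-difluorobenzyl on an amine nitrogen in a ring. All three measured steps exchange one aromatic ring for another on the saturated chain carbon bound to the amine nitrogen in a ring, and each keeps that carbon in place. For the measured compounds named here, none of them removes the carbon or sets an aromatic ring directly on the ring nitrogen, so no measured step bears directly on the change to compound 4. What the measured compounds do show is that changing the aromatic ring at that position moved this assay only within a modest span. With the attachment itself altered, a larger and less certain effect is expected, more likely toward a higher number.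

For compound 4 the estimate in this assay is 25 nM, with a range from 4 nM to 150 nM. The expected step from compound 3 is a 3.6-fold higher number from compound 3 to compound 4 (0.55 log units; beyond the scatter).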

Compound 4, half-maximal inhibitory concentration: 6 nM
Estimate against measurement, compound 4: 4.2-fold (0.62 log units) above, and the stated range covers the measured number.
By their numbers in this assay, from the lowest: compound 2; then compounds 1, 4 and 3 (each within the scatter of the next).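

In this assay, phenyl set directly on the amine nitrogen in a ring gives a 1.2-fold lower number from compound 3 to compound 4 (0.07 log units; within the scatter), so at this position the number stays level with that of compound 3 even though the 2,4-difluorobenzyl group, with its saturated chain carbon, has gone. The same holds against the (5-chlorothiophen-2-yl)methyl group, with a 1.5-fold higher number from compound 1 to compound 4 (0.18 log units; within the scatter), whereas the 4-bromobenzyl group alone stands apart, with a 6.0-fold higher number from compound 2 to compound 4 (0.78 log units; beyond the scatter); the saturated chain carbon is therefore not required for a low number in this assay, and of the groups compared only the 4-bromobenzyl group gives a number beyond the scatter of phenyl. Nothing at hand explains why removing that carbon leaves the number in this range.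

Still open, as far as these compounds go, is whether the advantage of the 4-bromobenzyl group carries over to 4-bromophenyl on the ring nitrogen, which would show whether the bromine or the benzyl attachment accounts for the gap to compound 4. Also open, from the compounds shown here alone, is how far this position tolerates a longer chain such as 2-phenylethyl, or a non-aromatic group such as cyclohexyl, in place of the aromatic ring.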